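The source may hold more compounds than are shown below. What is called first, only, known or untested is meant among the compounds shown, and "the series" means these compounds.

Of the compounds shown here, three that share a common core have been measured in an assay on isolated protein for inhibition of protein deacetylase HDAC6 (Homo sapiens), read by fluorescence; on this read-out higher numbers stand for weaker inhibition and lower numbers for stronger inhibition. Compound 1 `Cn1cc(-c2ccccc2Oc2ccccc2)c2cc(C(=O)NCCCCCCC(=O)NO)[nH]c2c1=O` gives 4.7 nM, while compound 3 `Cn1cc(-c2ccccc2Oc2ccccc2)c2cc(C(=O)NCc3ccc(C(=O)NO)cc3)[nH]c2c1=O` gives 15.3 nM. The change between them is 4-(hydroxycarbamoyl)phenyl in place of 5-(hydroxycarbamoyl)pentyl on a saturated chain carbon bound to an amide-type nitrogen, and it moved the number by a 3.3-fold higher number from compound 1 to compound 3 (0.51 log units; beyond the scatter). Compound 2 `Cn1cc(-c2cc(C(C)(C)O)ccc2OC2CC2)c2cc(C(=O)NCCCCCCC(=O)NO)[nH]c2c1=O` gives 5.5 nM in this assay, a value within the scatter of that of compound 1; the difference between the cores of compound 1 and compound 2 is not broken down here. Compound 4 `Cn1cc(-c2cc(C(C)(C)O)ccc2OC2CC2)c2cc(C(=O)NCc3ccc(C(=O)NO)cc3)[nH]c2c1=O` has not yet been measured. It differs from compound 2 by 4-(hydroxycarbamoyl)phenyl in place of 5-(hydroxycarbamoyl)pentyl on a saturated chain carbon bound to an amide-type nitrogen, the same change at the same place as that from compound 1 to compound 3. Because compound 2 gives 5.5 nM and the earlier change moved by a 3.3-fold higher number from compound 1 to compound 3 (0.51 log units; beyond the scatter), a step of a 3.3-fold higher number from compound 2 to compound 4 (0.51 log units; beyond the scatter) is expected in this assay. Compound 4 is therefore estimated at 18 nM, with a likely range from 8 nM to 40 nM.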

Compound 4, half-maximal inhibitory concentration: 7.9 nM
Estimate against measurement, compound 4: 2.3-fold (0.36 log units) above; the whole stated range lies above it.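

On the core of compound 2, 4-(hydroxycarbamoyl)phenyl in place of 5-(hydroxycarbamoyl)pentyl gave a 1.4-fold higher number from compound 2 to compound 4 (0.16 log units; within the scatter) in this assay. The step read beyond the scatter on one core and within it on the other, yet the two steps cannot be told apart: the same change on two cores in this assay, a 3.3-fold higher number (0.51 log units; beyond the scatter) from compound 1 to compound 3 and a 1.4-fold higher number (0.16 log units; within the scatter) from compound 2 to compound 4, 2.3-fold (0.36 log units) apart, within the scatter of two such steps. The change is thus compatible with carrying over from one core to the other, but two pairs establish no general rule for the series and cannot show that its size is truly the same on both cores.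

The compounds shown leave open how a longer chain bearing the hydroxycarbamoyl group would behave on these cores. They also leave open whether a carboxylic acid in place of the hydroxycarbamoyl group would follow the same course.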